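Replacing a Methyl with an Extended Amide Arm

The source may hold more compounds than are shown below. What is called first, only, known or untested is meant among the compounds shown, and "the series" means these compounds.

Compound 1 `Cc1ccc(N2C(=O)N/C(=C\c3ccc(O)cc3)C2=O)cc1` is assessed in a functional assay on NCI-H292 cells (Homo sapiens) for antiproliferative activity; a higher number here means a weaker inhibitor, a lower number a stronger inhibitor. In this assay compound 1 gives 27900 nM, the only numeric result among the two measured compounds. Compound 2 `Cc1cccc(N2C(=O)N/C(=C\c3ccc(O)cc3)C2=O)c1` differs from it by a 3-methylphenyl in place of the 4-methylphenyl on the amide-type nitrogen of the shared core. In this assay compound 2 gives > 200000 nM, which is a limit of the assay rather than a number (the limit of > 200000 nM in this assay, at which 1 of the 2 values shown sits). The resulting step is an at least 7.1-fold higher number from compound 1 to compound 2 (0.85 log units; beyond the scatter). Compound 3 `O=C(Nc1ccc(Cl)cc1)c1ccc(N2C(=O)N/C(=C\c3ccc(O)cc3)C2=O)cc1` keeps the arrangement of compound 1 and instead changes the substituent itself: (4-chlorophenyl)carbamoyl in place of methyl on an aromatic carbon. Within the data shown here, no measured step concerns this kind of change; the single measured step deals only with where a methyl sits, so it gives no guide to the size or direction of the step in this assay here. Compound 3 is therefore expected to land near 10000 nM, with a range from 2000 nM to 60000 nM. This estimate means that a step of a 2.8-fold lower number from compound 1 to compound 3 (0.45 log units; beyond the scatter) is expected.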

Compound 3, half-maximal inhibitory concentration: > 200000 nM
Compound 3 ended at the assay's limit (the forecaster's own chance of this, stated with the estimate: 10%); middle value at least 20-fold (1.30 log units) away from the limit.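

Replacing the methyl of compound 1 with the much larger (4-chlorophenyl)carbamoyl arm on the same aromatic carbon gives an at least 7.1-fold higher number from compound 1 to compound 3 (0.85 log units; beyond the scatter) in this assay. The earlier step only moved a methyl, whereas this one shows that the position does not simply accept an extended amide arm carrying a second aromatic ring. Compound 3 stands at a limit of the assay rather than at a number, so its step marks only the least possible loss, and compound 3 cannot be ranked against compound 2: the limit of > 200000 nM in this assay, at which 2 of the 3 values shown sit.

On these data alone, it remains open whether a small group at this position, such as a hydroxyl, an amine or a carboxylic acid, would match or improve on compound 1. The compounds shown also do not separate the effect of the amide link from that of the 4-chlorophenyl ring, a question that a plain carbamoyl group could address.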